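Compound 3 to compound 4: thiophen-2-yl for 3-aminophenyl

The compounds below may be only part of what the source reports. "The series", "measured", "known", "first", "only" and "open" are said of these compounds alone.

Compound 1 `COc1ccc(-c2nc3cccc(-c4cc(OC)c(OC)c(OC)c4)c3o2)cc1F` gives 1800 nM
Compound 2 `COc1cc(-c2cccc3nc(-c4ccc(N)cc4)oc23)cc(OC)c1OC` gives 720 nM
Compound 3 `COc1cc(-c2cccc3nc(-c4cccc(N)c4)oc23)cc(OC)c1OC` gives 4700 nM

In a functional assay on A549 cells (Homo sapiens) for antiproliferative activity, read by MTT assay, with a stated time of 48 h (a higher number here means a weaker inhibitor, a lower number a stronger inhibitor), compound 3 gives 4700 nM and stands highest of the three, beyond the scatter from both others. Compound 4 `COc1cc(-c2cccc3nc(-c4cccs4)oc23)cc(OC)c1OC` carries thiophen-2-yl in place of 3-aminophenyl on an aromatic carbon, next to the ring nitrogen and next to the ring oxygen. The change counts as thiophen-2-yl in place of 3-aminophenyl on an aromatic carbon and stays at the place varied in all three measured steps. These are a 6.5-fold higher number from compound 2 to compound 3 (0.81 log units; beyond the scatter) as the largest, then a 2.6-fold higher number from compound 1 to compound 3 (0.42 log units; beyond the scatter) and a 2.5-fold lower number from compound 1 to compound 2 (0.40 log units; beyond the scatter) as the smaller two, all modest. None of them involves thiophen-2-yl, so the data give no direct measure of this group. Compound 3 sits at the top of the range, and both other groups at this place give lower numbers. An estimated 2.4-fold lower number from compound 3 to compound 4 (0.37 log units; beyond the scatter) is therefore expected, a modest step in the direction of a lower number. The expected value for compound 4 is 2000 nM within an estimated range from 600 nM to 6000 nM for now.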

Compound 4, half-maximal inhibitory concentration: 12500 nM
Estimate against measurement, compound 4: 6.3-fold (0.80 log units) below; measured number outside the range, above it.
By their numbers in this assay, from the lowest: compound 2; then compound 1; then compound 3; then compound 4.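

In this assay thiophen-2-yl, the first five-membered ring at this place, sits above all three six-membered aromatic groups (a 2.7-fold higher number from compound 3 to compound 4 (0.42 log units; beyond the scatter)) and (a 6.9-fold higher number from compound 1 to compound 4 (0.84 log units; beyond the scatter)) and (a 17-fold higher number from compound 2 to compound 4 (1.24 log units; beyond the scatter)), and this gives the series its first large step at this place. Compound 1 carries no amine yet still gives a lower number than compound 4, so an amine on the aryl group is not required for a number below that of compound 4. Nothing available here accounts for the rise in number with thiophen-2-yl.

As far as these compounds go, whether the rise goes with the ring size, the sulfur or the loss of the amine stays open. An unsubstituted phenyl or a furan-2-yl at this place would help separate these, as would an amine on the thiophene ring.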